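Boronic acid analogues on a shared naphthol core

A few compounds are considered here, and "the series" means these few. Any claim that something is new, unique, unknown or untested is made for them only; others in the source may bear on it.

Measured compounds:
compound 1 `CC(C)C[C@H](NC(=O)CSc1cc(NS(=O)(=O)c2cccs2)c2ccccc2c1O)B(O)O` — 7540 nM
compound 2 `CC(=O)Nc1ccc(S(=O)(=O)Nc2cc(SCC(=O)N[C@@H](CC(C)C)B(O)O)c(O)c3ccccc23)cc1` — 6700 nM
compound 3 `CC(C)C[C@H](NC(=O)C(C)Sc1cc(NS(=O)(=O)c2cccs2)c2ccccc2c1O)B(O)O` — 11300 nM

In a functional assay on A549 cells (Homo sapiens) for antiproliferative activity, read by sulforhodamine B assay, with a stated time of 72 h (a lower number here means a stronger inhibitor, a higher number a weaker inhibitor), compound 1 gives 7540 nM. Compound 2 carries 4-acetamidophenyl in place of thiophen-2-yl on a sulfonyl sulfur and shows a 1.1-fold lower number from compound 1 to compound 2 (0.05 log units; within the scatter). Compound 3 differs from compound 1 in that its core carries methyl in place of hydrogen on a saturated chain carbon bound to a carbonyl carbon and a sulfur, giving a 1.5-fold higher number from compound 1 to compound 3 (0.18 log units; within the scatter). Compound 4 `CC(=O)Nc1ccc(S(=O)(=O)Nc2cc(SC(C)C(=O)N[C@@H](CC(C)C)B(O)O)c(O)c3ccccc23)cc1` is not yet measured in this assay. For the measured compounds named here, it differs from compound 3 by 4-acetamidophenyl in place of thiophen-2-yl on a sulfonyl sulfur, a change that is the same as the one from compound 1 to compound 2, with the same place on both cores. That earlier change gave a 1.1-fold lower number from compound 1 to compound 2 (0.05 log units; within the scatter), a step within the scatter. The step from compound 3 to compound 4 is expected to be of similar size, a 1.1-fold lower number from compound 3 to compound 4 (0.05 log units; within the scatter), because the same change on the core of compound 1 gave a 1.1-fold lower number from compound 1 to compound 2 (0.05 log units; within the scatter) and the cores of compound 1 and compound 3 differ only by methyl in place of hydrogen on a saturated chain carbon bound to a carbonyl carbon and a sulfur. Compound 4 is therefore estimated at 10000 nM in this assay, with an expected range from 5000 nM to 22000 nM.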

Compound 4, half-maximal inhibitory concentration: 6370 nM
Compound 4: middle estimate off by 1.6-fold (0.20 log units), on the high side; the range from low to high includes it.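

In this assay, for the compounds shown here, 4-acetamidophenyl in place of thiophen-2-yl on a sulfonyl sulfur gives a 1.8-fold lower number from compound 3 to compound 4 (0.25 log units; within the scatter), and this step does not differ from the one the same change gave on the other core: the same change on two cores in this assay, a 1.1-fold lower number (0.05 log units; within the scatter) from compound 1 to compound 2 and a 1.8-fold lower number (0.25 log units; within the scatter) from compound 3 to compound 4, 1.6-fold (0.20 log units) apart, within the scatter of two such steps. Methyl in place of hydrogen on a saturated chain carbon bound to a carbonyl carbon and a sulfur gives a 1.1-fold lower number from compound 2 to compound 4 (0.02 log units; within the scatter), and this step likewise does not differ from its earlier counterpart: the same change on two cores in this assay, a 1.5-fold higher number (0.18 log units; within the scatter) from compound 1 to compound 3 and a 1.1-fold lower number (0.02 log units; within the scatter) from compound 2 to compound 4, 1.6-fold (0.20 log units) apart, within the scatter of two such steps. Across these four compounds, each change therefore carries from one core to the other without a visible difference, but every step lies within the scatter, so this shows only that neither change moves the number measurably here, not that a larger effect would carry over in the same way.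

The compounds shown leave open whether an amine or a carboxylic acid in place of the acetamido group would give a step beyond the scatter. They also leave open whether a longer chain in place of the methyl would do so.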